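A Dimethylphenyl Swap on the Carbonyl Carbon

The compounds below may be only part of what the source reports. "The series", "measured", "known", "first", "only" and "open" are said of these compounds alone.

Compound 1 (`CCCC(C)Oc1ccc(C(=O)/C=C/c2c(/C=C/c3ccc(OC)cc3)cc(OC)cc2OC)cc1`), compound 2 (`COc1ccc(/C=C/c2cc(OC)cc(OC)c2/C=C/C(=O)c2cccc(Cl)c2)cc1`) and compound 3 (`COc1ccc(/C=C/c2cc(OC)cc(OC)c2/C=C/C(=O)c2ccc(C(F)(F)F)cc2)cc1`) share one core and differ in the group on the carbonyl carbon. In a functional assay on B16-F10 cells (Mus musculus) for antiproliferative activity, read by MTT assay, with a stated time of 48 h (on this read-out lower numbers stand for stronger inhibition and higher numbers for weaker inhibition), compound 1 gives 6.7 ug/mL while compound 2 gives 3.3 ug/mL and compound 3 gives 4.3 ug/mL on the same read-out. Compound 3 therefore cannot be told apart from either of the others: the data show a 1.6-fold lower number from compound 1 to compound 3 (0.19 log units; within the scatter) and a 1.3-fold higher number from compound 2 to compound 3 (0.11 log units; within the scatter) and both lie within the scatter.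

Compound 4 (`COc1ccc(/C=C/c2cc(OC)cc(OC)c2/C=C/C(=O)c2ccc(C)cc2C)cc1`) carries 2,4-dimethylphenyl in place of 4-(trifluoromethyl)phenyl on a carbonyl carbon, a change counted as 2,4-dimethylphenyl in place of 4-(trifluoromethyl)phenyl on a carbonyl carbon in full. All three measured steps change the group at this same place, so all three bear on it. The widest of them, from the pair compound 1 and compound 2, is a 2.0-fold lower number from compound 1 to compound 2 (0.31 log units; beyond the scatter) and is only modest. Among the compounds with values here, no measured compound carries the 2,4-dimethylphenyl group, so the data offer no direct reading of it. In this assay the expected change is a 1.0-fold higher number from compound 3 to compound 4 (0.02 log units; within the scatter) and no step beyond the scatter is expected. For compound 4 the estimated value is 4.5 ug/mL with an expected range from 2.2 ug/mL to 9 ug/mL around it.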

Compound 4, half-maximal inhibitory concentration: 4 ug/mL
Beside the measured number, compound 4's estimate is 1.1-fold (0.05 log units) above it, and the stated range covers the measured number.
By their numbers in this assay, from the lowest: compounds 2, 4, 3 and 1 (each within the scatter of the next, the first and the last beyond it).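

Compound 4 places an all-carbon group, 2,4-dimethylphenyl, on the carbonyl carbon, and in this assay all three steps that reach it, a 1.1-fold lower number from compound 3 to compound 4 (0.03 log units; within the scatter) and a 1.2-fold higher number from compound 2 to compound 4 (0.08 log units; within the scatter) and a 1.7-fold lower number from compound 1 to compound 4 (0.22 log units; within the scatter), lie within the scatter. Within the data shown here, the numbers at this place therefore do not depend on a halogen on the phenyl ring, since a group with neither fluorine nor chlorine cannot be told apart from the trifluoromethyl and chloro compounds, and the only step beyond the scatter remains a 2.0-fold lower number from compound 1 to compound 2 (0.31 log units; beyond the scatter), which compound 4 neither widens nor helps to explain. Nothing at hand accounts for why these groups give such similar numbers.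

Since 2,4-dimethylphenyl carries two methyl groups at once, the compounds shown cannot separate their contributions, and a phenyl ring with a single methyl group would be needed for that. They also leave open whether an amine or a carboxylic acid on this phenyl ring, or a saturated ring such as cyclohexyl in its place, would stay within the same narrow band of numbers or move clearly outside it.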